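Heteroaryl amides of a chlorophenyl valeramide core: compound 4

A few compounds are considered here, and "the series" means these few. Any claim that something is new, unique, unknown or untested is made for them only; others in the source may bear on it.

Measured so far:
compound 1 `CC(C)[C@H](C(=O)Nc1ccccc1)c1ccc(Cl)cc1` — > 100000 nM (a limit)
compound 2 `CC(C)[C@H](C(=O)Nc1ccccn1)c1ccc(Cl)cc1` — 1400 nM
compound 3 `CC(C)[C@H](C(=O)Nc1nncs1)c1ccc(Cl)cc1` — 12000 nM

In a functional assay on CHO cells for agonist activity at Free fatty acid receptor 2 (Homo sapiens), read by cAMP accumulation (on this read-out lower numbers stand for stronger inhibition and higher numbers for weaker inhibition), compound 1 reaches only the assay limit, at > 100000 nM. In this assay compound 2 gives 1400 nM and compound 3 gives 12000 nM, the higher of the two numbers; the step of an 8.6-fold higher number from compound 2 to compound 3 (0.93 log units; beyond the scatter) sets it apart from compound 2, and the step of an at least 8.3-fold lower number from compound 1 to compound 3 (0.92 log units; beyond the scatter) places it below the limit of compound 1.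

Compound 4 `CC(C)[C@H](C(=O)Nc1ccon1)c1ccc(Cl)cc1` differs from compound 3 by 1,2-oxazol-3-yl in place of 1,3,4-thiadiazol-2-yl on an amide-type nitrogen. Every measured step here changes the group on the amide-type nitrogen: an at least 71-fold lower number from compound 1 to compound 2 (1.85 log units; beyond the scatter) and an at least 8.3-fold lower number from compound 1 to compound 3 (0.92 log units; beyond the scatter) leave the limit behind, while an 8.6-fold higher number from compound 2 to compound 3 (0.93 log units; beyond the scatter) is modest. Both five-membered rings carry no hydrogen-bond donors and differ only in hetero atom count, so a step within the scatter, or a small rise, is expected for compound 4, namely a 1.3-fold higher number from compound 3 to compound 4 (0.10 log units; within the scatter). Compound 4 is therefore estimated at 15000 nM, with a range of 4000 nM to 60000 nM in this assay.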

Compound 4, half-maximal inhibitory concentration: 36000 nM
For compound 4 the middle estimate is 2.4-fold (0.38 log units) below the measured one; the range from low to high includes it.
By their numbers in this assay, from the lowest: compound 2; then compound 3; then compound 4. At a limit, above all of these: compound 1.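

Changing one five-membered ring for another on the amide-type nitrogen is not a neutral swap in this assay: although both rings carry no hydrogen-bond donors, the result is a 3.0-fold higher number from compound 3 to compound 4 (0.48 log units; beyond the scatter). The gap to the six-membered pyridin-2-yl group is wider, at a 26-fold higher number from compound 2 to compound 4 (1.41 log units; beyond the scatter), so pyridin-2-yl keeps the lowest number of the groups shown and neither five-membered ring comes close to it. The 1,2-oxazol-3-yl group still improves on phenyl, with an at least 2.7-fold lower number from compound 1 to compound 4 (0.44 log units; beyond the scatter), but this step rests on a limit: the limit of > 100000 nM in this assay, at which 1 of the 4 values shown sits.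

As far as these compounds go, it remains open whether a pyrimidin-2-yl ring, or a pyridin-2-yl ring bearing a methyl or fluoro group, would match or improve on compound 2. Also open, from the compounds shown here alone, is how the number would respond if a methoxy group replaced the chloro group on the shared core.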